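Swapping fluoro for methyl on a fused aromatic ring

The source may hold more compounds than are shown below. What is called first, only, known or untested is meant among the compounds shown, and "the series" means these compounds.

Of the compounds shown here, three have been measured in an assay on isolated protein for displacement of a labelled ligand from metabotropic glutamate receptor 5 (Homo sapiens), with a stated time of 60 min, tested at 1 uM; on this read-out lower numbers stand for less inhibition and higher numbers for more inhibition at the one concentration tested (going by the name of the read-out). Within the data shown here, compound 1 `Cc1ccc2ncc(S(=O)(=O)c3ccccc3)c(N3CCC(C)CC3)c2c1` gives 67%, and compound 2 `Cc1ccc2ncc(S(=O)(=O)c3cc(Cl)cc(Cl)c3)c(N3CCC(C)CC3)c2c1` gives 75%; the step of a number 8 percentage points higher from compound 1 to compound 2 (within the scatter) is the only change between measured compounds that differ in one place. Compound 3 `CC1CCN(c2c(S(=O)(=O)c3ccc(Cl)c(Cl)c3)cnc3ccc(F)cc23)CC1` gives 91%, the highest number of the three, standing beyond the scatter above both compound 2 and compound 1.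

Compound 4 `Cc1ccc2ncc(S(=O)(=O)c3ccc(Cl)c(Cl)c3)c(N3CCC(C)CC3)c2c1` is compound 3 with one change: methyl in place of fluoro on an aromatic carbon. Among the measured compounds shown here, no measured step bears directly on this exchange, since the one measured step concerns a dichlorophenyl pattern on the sulfonyl sulfur, not the fused ring. Compound 2 and compound 4 share the methyl on the fused ring but carry differently placed chlorines, so their values are not a clean comparison either.

With no direct guide, a small step is expected in this assay: compound 4 is estimated at 85%, between 72% and 95%. The expected step is a number 6 percentage points lower from compound 3 to compound 4 (within the scatter), which lies within the scatter.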

Compound 4, a percentage reported as inhibition, at one concentration (the size of the read-out at that concentration, not a potency): 82%
Estimate against measurement, compound 4: 3 percentage points above, within the range that was stated.
By their numbers in this assay, from the lowest: compounds 1, 2, 4 and 3 (each within the scatter of the next, the first and the last beyond it).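

In this assay, fluoro and methyl at this place on the fused ring now have a direct comparison, a number 9 percentage points lower from compound 3 to compound 4 (within the scatter), so the exchange shows no clear difference here. Among these compounds, with the methyl kept, changing the chlorine pattern gives a number 7 percentage points higher from compound 2 to compound 4 (within the scatter), whereas the comparison with the unsubstituted phenyl gives a number 15 percentage points higher from compound 1 to compound 4 (beyond the scatter), the first single change on the sulfonyl-bound ring in this set to pass beyond the scatter. No supporting measurement is available to explain the size of these steps.

Fluoro and methyl are the only groups shown at this place, so it remains open how a methoxy group, an amine or a carboxylic acid there would read out. On these data alone, it is also open whether a single chlorine on the phenyl ring would be enough to give a step of this size.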